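A few compounds are considered here, and "the series" means these few. Any claim that something is new, unique, unknown or untested is made for them only; others in the source may bear on it.

Of the compounds shown here, three built on one shared core have been measured in a functional assay for inhibition, with Homo sapiens as the target; on this read-out higher numbers stand for weaker inhibition and lower numbers for stronger inhibition. Compound 1 `CC(C)(C)Sc1c(CC(C)(C)C(=O)O)n(Cc2ccc(Cl)cc2)c2ccc(OCc3nc4cc(C(F)(F)F)ccc4s3)cc12` gives 22 nM in this assay. Compound 2 `Cc1nc2ccc(COc3ccc4c(c3)c(SC(C)(C)C)c(CC(C)(C)C(=O)O)n4Cc3ccc(Cl)cc3)cc2s1` gives 6 nM in this assay. For compound 3 `CC(C)(C)Sc1c(CC(C)(C)C(=O)O)n(Cc2ccc(Cl)cc2)c2ccc(OCc3nc4ccccc4o3)cc12` the assay reports only a limit, < 7 nM, rather than a number. Because of this limit of < 7 nM in this assay, at which 1 of the 3 values shown sits, the step that the limit leaves unreadable from compound 2 to compound 3 cannot be read in size, and where compound 3 stands among the three is known only as a limit, not as a place in an order. Compound 4 `CC(C)c1csc(COc2ccc3c(c2)c(SC(C)(C)C)c(CC(C)(C)C(=O)O)n3Cc2ccc(Cl)cc2)n1` differs from compound 3 in one place: 4-isopropyl-1,3-thiazol-2-yl in place of 1,3-benzoxazol-2-yl on a saturated chain carbon bound to an oxygen on an aromatic ring. Among the measured compounds shown here, no measured step concerns this particular exchange; the only step at the same place is the unreadable one. The expected step of an at least 1.4-fold higher number from compound 3 to compound 4 (0.15 log units; that floor lies within the scatter) therefore rests on the spread of the three values alone and is expected to be modest, in either direction, with no clear lean. Compound 4 is estimated at 10 nM, with a range from 3 nM to 40 nM.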

Compound 4, half-maximal inhibitory concentration: 3 nM
For compound 4 the middle estimate is 3.3-fold (0.52 log units) above the measured one; low and high end bracket the measured number.
By their numbers in this assay, from the lowest: compounds 4 and 2 (each within the scatter of the next); then compound 1.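

In this assay, the exchange of 2-methyl-1,3-benzothiazol-6-yl for 4-isopropyl-1,3-thiazol-2-yl gives a 2.0-fold lower number from compound 2 to compound 4 (0.30 log units; within the scatter). Compound 4 thus shows that, on a saturated chain carbon bound to an oxygen on an aromatic ring, a group with one five-membered aromatic ring and no six-membered ring can still give a value in the same range as compound 2. The step from compound 3 to compound 4 cannot be read in size because compound 3 carries only a limit: the limit of < 7 nM in this assay, at which 1 of the 4 values shown sits.

Going by these compounds, what the isopropyl group itself adds stays open, and a 1,3-thiazol-2-yl with a methyl or an amine in its place would speak to that. Also open, on these data alone, is how a group with no aromatic ring, such as a plain longer carbon chain, would read in this assay.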